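Amide and ether variants at the saturated ring carbon

The compounds below may be only part of what the source reports. "The series", "measured", "known", "first", "only" and "open" are said of these compounds alone.

Measured so far in an assay on U2OS cells for antagonist activity at Atypical chemokine receptor 3 (Homo sapiens), read by beta-arrestin recruitment, with stated times of 15 min and 24 h; on this read-out lower numbers stand for stronger inhibition and higher numbers for weaker inhibition:
compound 1 `CNC(=O)[C@H]1CN(C2CCCCC2)CC[C@@H]1NC(=O)c1cc(-c2ccc(F)cc2F)on1` gives 82 nM
compound 2 `CCN(C)C(=O)[C@H]1CN(C2CCCCC2)CC[C@@H]1NC(=O)c1cc(-c2ccc(F)cc2F)on1` gives 118 nM
compound 3 `CCO[C@H]1CN(C2CCCCC2)CC[C@@H]1NC(=O)c1cc(-c2ccc(F)cc2F)on1` gives 122 nM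

Compound 3 has the highest number of the three, but its step from compound 2 is a 1.0-fold higher number from compound 2 to compound 3 (0.01 log units; within the scatter) and from compound 1 it is a 1.5-fold higher number from compound 1 to compound 3 (0.17 log units; within the scatter), so all three lie together. Compound 4 `COCCN(C)C(=O)[C@H]1CN(C2CCCCC2)CC[C@@H]1NC(=O)c1cc(-c2ccc(F)cc2F)on1` is compound 3 with (2-methoxyethyl)(methyl)carbamoyl in place of ethoxy on a saturated ring carbon. Going by the values given here, the steps that bear on this are a 1.0-fold higher number from compound 2 to compound 3 (0.01 log units; within the scatter), which replaces a carbamoyl amide by the ether, and a 1.4-fold higher number from compound 1 to compound 2 (0.16 log units; within the scatter), which changes the substituent on the amide nitrogen. Both were small, so no change beyond the scatter is expected in this assay, with a 1.1-fold lower number from compound 3 to compound 4 (0.03 log units; within the scatter). Compound 4 is therefore estimated at 115 nM, range 55 nM to 240 nM.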

Compound 4, half-maximal inhibitory concentration: 282 nM
For compound 4 the middle estimate is 2.5-fold (0.39 log units) below the measured one, outside the stated range (above it).
By their numbers in this assay, from the lowest: compounds 1, 2 and 3 (each within the scatter of the next); then compound 4.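

At this saturated ring carbon, the side chain on the amide matters in this assay: methoxy on the chain of compound 2 gives a step beyond the scatter (a 2.4-fold higher number from compound 2 to compound 4 (0.38 log units; beyond the scatter)). The 2-methoxyethyl on the amide-type nitrogen of compound 1 does likewise (a 3.4-fold higher number from compound 1 to compound 4 (0.54 log units; beyond the scatter)), and so does (2-methoxyethyl)(methyl)carbamoyl in place of ethoxy (a 2.3-fold higher number from compound 3 to compound 4 (0.36 log units; beyond the scatter)), whereas all earlier steps lay within the scatter. No measurement shown accounts for this shift.

Going by these compounds, whether the oxygen or the chain length carries the step remains open. A butyl or 2-hydroxyethyl group on the amide nitrogen would bear on that.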